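Nitro for Chloro on the Aryl of Compound 3

This account rests on a few compounds, and the source may have more. Where it says the series, first, only, none or still open, it means among the compounds named here.

Measured so far:
Compound 1 `CCn1nc(C)c2nc(-c3ccccc3)nc(O)c21` — 670 nM
Compound 2 `Cc1nn(C)c2c(O)nc(-c3ccccc3)nc12` — 1020 nM
Compound 3 `Cn1c(=O)c2nc(-c3ccc(Cl)cc3)[nH]c2n(C)c1=O` — 0.8 nM

Of the compounds shown here, three have been measured in an assay on membranes from brain for binding affinity to adenosine receptor A1 (Rattus norvegicus), read by radioligand binding; a higher number here means a weaker inhibitor, a lower number a stronger inhibitor. For the measured compounds named here, compound 1 gives 670 nM and compound 2 gives 1020 nM; the only single-point step among them, a 1.5-fold higher number from compound 1 to compound 2 (0.18 log units; within the scatter), is a change of hydrogen in place of methyl on a saturated chain carbon bound to an aromatic nitrogen. Compound 3 stands apart from both: in this assay it gives 0.8 nM, the lowest of the three numbers, far beyond the scatter from either compound 1 or compound 2.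

Compound 4 `Cn1c(=O)c2nc(-c3ccc([N+](=O)[O-])cc3)[nH]c2n(C)c1=O` has not yet been measured. It differs from compound 3 in one place: nitro in place of chloro on an aromatic carbon, on an aromatic carbon of a six-membered aromatic ring of carbon only, para to a large group. Going by the values given here, no measured step concerns an exchange of one group for another on that ring; the step from compound 1 to compound 2 sits on a different part of the core and is within the scatter, so it offers no guidance on direction or size. The expectation for compound 4 therefore rests on compound 3 alone, with a modest allowance for change in either direction, as a 3.8-fold higher number from compound 3 to compound 4 (0.57 log units; beyond the scatter). Compound 4 is estimated at 3 nM, in the range 0.8 nM to 12 nM.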

Compound 4, half-maximal inhibitory concentration: 8 nM
Compound 4: middle estimate off by 2.7-fold (0.43 log units), on the low side; the range from low to high includes it.
By their numbers in this assay, from the lowest: compound 3; then compound 4; then compounds 1 and 2 (each within the scatter of the next).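

In this assay, for the compounds shown here, the exchange of nitro for chloro on an aromatic carbon, para to a large group, gives a 10-fold higher number from compound 3 to compound 4 (1.00 log units; beyond the scatter) and is the first reading of a change on this ring. Going by these compounds alone, it shows that the number responds to which group stands at this place, and that the response lies beyond the scatter, unlike the only earlier step, a 1.5-fold higher number from compound 1 to compound 2 (0.18 log units; within the scatter) on a different part of the core. This single pair gives the direction and size of the shift for these two groups only, and nothing at hand accounts for it, with no measurement offered that bears on the result.

Only chloro and nitro are shown on this aromatic carbon, so it remains open whether an amine, a carboxylic acid, a methoxy group or plain hydrogen there would fall near compound 3, near compound 4 or outside both. As far as these compounds go, it also remains open whether nitro in place of chloro would move the number in the same direction and by a similar amount on the core of compound 1, or at another carbon of the same ring.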